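The source may report more compounds than this note shows. Statements on the series, on what has been measured and on what is new or still open speak of the compounds shown alone.

Two members of the series have been run in a functional assay on MV4-11 cells (Homo sapiens) for inhibition, with a stated time of 120 h, tested at 10 uM; a lower number here means less inhibition, a higher number more inhibition at the concentration tested (going by the name of the read-out). Compound 1, `COc1ccc(Nc2c(-c3ccc4[nH]nc(C)c4c3)nc3cnc(N4CCN(C)CC4)cn23)cc1`, gives 3.32% in this assay, and compound 2, `Cc1ccc(C)c(Nc2c(-c3ccc4[nH]nc(C)c4c3)nc3cnc(N4CCN(C)CC4)cn23)c1`, gives 0%. Within the data shown here, the only step between them, a number 3.3 percentage points lower from compound 1 to compound 2 (within the scatter), swaps the aryl group on the amine nitrogen and moves the read-out by no more than the scatter. Among the measured compounds shown here, compound 2 thus stands at the lower of the two numbers, with compound 1 as its sole neighbour and within the scatter of it.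

Compound 3, `Cc1n[nH]c2ccc(-c3nc4cnc(N5CCN(C)CC5)cn4c3Nc3ccc(F)cc3Br)cc12`, differs from compound 2 in the same position: 2-bromo-4-fluorophenyl in place of 2,5-dimethylphenyl on a nitrogen on an aromatic ring. For the measured compounds named here, the single step that bears on this change is the aryl swap from compound 1 to compound 2, which stayed within the scatter, so for compound 3 no step beyond the scatter is expected in this assay, in either direction, and the estimated change is a number 3 percentage points higher from compound 2 to compound 3 (within the scatter). Compound 3 is therefore expected to give about 3%, in the range 0% to 15%.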

Compound 3, a percentage reported as inhibition, at one concentration (the size of the read-out at that concentration, not a potency): 82.4%
Compound 3: the middle estimate sits 79.4 percentage points below what was measured; measured number outside the range, above it.
By their numbers in this assay, from the lowest: compounds 2 and 1 (each within the scatter of the next); then compound 3.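

In this assay the aryl group on the amine nitrogen proves to be far from silent: the change to 2-bromo-4-fluorophenyl from 2,5-dimethylphenyl reads a number 82.4 percentage points higher from compound 2 to compound 3 (beyond the scatter) and the change to the same group from 4-methoxyphenyl reads a number 79.1 percentage points higher from compound 1 to compound 3 (beyond the scatter) at the same place. Among these compounds, the earlier step within the scatter therefore describes only the pair of 4-methoxyphenyl and 2,5-dimethylphenyl, not the position as a whole. Nothing at hand bears on why this change has so large an effect.

Bromine and fluorine enter together in compound 3, so it remains open whether either halogen alone on the phenyl ring carries the step. Also open, as far as these compounds go, is how the position responds to other groups on that nitrogen, such as a pyridine ring or a cyclohexyl ring.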